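From Acetyl to Chloro: One Substituent, One Expected Shift

The compounds below may be only part of what the source reports. "The series", "measured", "known", "first", "only" and "open" are said of these compounds alone.

Within the data shown here, compound 2 `CC(=O)c1cnc(N2CCC(c3coc4c(N5CCc6cc(S(C)(=O)=O)ccc65)ncnc34)CC2)nc1` stands lowest of the two numbers measured so far in a functional assay on cells for agonist activity at Glucose-dependent insulinotropic receptor (Homo sapiens), read by a luciferase reporter, with a stated time of 4 h (a lower number here means that less compound is needed, a higher number that more compound is needed for the effect), where compound 2 gives 78 nM. Its nearest neighbour is compound 1 `Cc1cnc(N2CCC(c3coc4c(N5CCc6cc(S(C)(=O)=O)ccc65)ncnc34)CC2)nc1`, which in this assay gives 252 nM; the two are separated by a 3.2-fold lower number from compound 1 to compound 2 (0.51 log units; beyond the scatter). Compound 3 `CS(=O)(=O)c1ccc2c(c1)CCN2c1ncnc2c(C3CCN(c4ncc(Cl)cn4)CC3)coc12` has not yet been measured. It differs from compound 2 in a single place: chloro in place of acetyl on an aromatic carbon. Among the measured compounds shown here, the only measured step that bears on this position is a 3.2-fold lower number from compound 1 to compound 2 (0.51 log units; beyond the scatter), which shows that the group on this aromatic carbon can move the number beyond the scatter. Chloro, like methyl, brings no hydrogen-bond acceptor, whereas acetyl brings one, so compound 3 is expected to fall between compound 1 and compound 2, nearer to compound 1. The estimated step is a 2.3-fold higher number from compound 2 to compound 3 (0.36 log units; beyond the scatter). Compound 3 is therefore estimated at 180 nM, with a range of 60 nM to 550 nM.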

Compound 3, half-maximal effective concentration: 42 nM
The estimate for compound 3 lay 4.3-fold (0.63 log units) above the measured number, outside the stated range (below it).
By their numbers in this assay, from the lowest: compounds 3 and 2 (each within the scatter of the next); then compound 1.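

Chloro in place of acetyl gives a 1.9-fold lower number from compound 2 to compound 3 (0.27 log units; within the scatter) in this assay, so on this aromatic carbon the two groups cannot be told apart, although chloro brings no hydrogen-bond acceptor and acetyl brings one. Chloro in place of methyl gives a 6.0-fold lower number from compound 1 to compound 3 (0.78 log units; beyond the scatter) as a modest step, although neither group brings a hydrogen-bond acceptor. An acceptor on this carbon is therefore not needed for the lower numbers, and counting acceptors does not sort the three compounds, with compound 3 going against that reading. On these data alone, whether bromo, nitrile, methoxy or an amine on this carbon would stay with chloro and acetyl or fall back towards methyl remains open. Nothing shown here says why these groups differ as they do.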